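A chlorophenyl for a methoxyphenyl: what compound 4 may show

The source may report more compounds than this note shows. Statements on the series, on what has been measured and on what is new or still open speak of the compounds shown alone.

Among the compounds with values here, compound 1 `COc1cccc(-c2nc(SCC(=O)c3sc(-c4ccccc4)nc3C)[nH]c(=O)c2C#N)c1` is one of three compounds measured in a functional assay on U-87MG ATCC cells for antiproliferative activity against U-87 MG (Homo sapiens), read by MTT assay, with a stated time of 48 h, tested at 5 uM (a lower number here means a stronger effect, a higher number a weaker effect of the compound at the concentration tested), where compound 1 gives 99%. Compound 2 `COc1cccc(-c2nc(SCC(=O)c3sc(-c4ccc(Cl)cc4)nc3C)[nH]c(=O)c2C#N)c1` gives 96.6%, and compound 3 `COc1ccc(-c2nc(C)c(C(=O)CSc3nc(-c4cccc(OC)c4)c(C#N)c(=O)[nH]3)s2)cc1` gives 71.3%. Compound 1 thus shows the highest of the three numbers; its nearest neighbour is compound 2, a number 2.4 percentage points lower from compound 1 to compound 2 (within the scatter), and the furthest is compound 3, a number 27.7 percentage points lower from compound 1 to compound 3 (beyond the scatter). The remaining step, a number 25.3 percentage points lower from compound 2 to compound 3 (beyond the scatter), sets methoxy against chloro on the same aromatic carbon.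

Compound 4 `Cc1nc(-c2ccccc2)sc1C(=O)CSc1nc(-c2ccc(Cl)cc2)c(C#N)c(=O)[nH]1` has not yet been measured. It differs from compound 1 in one place: 4-chlorophenyl in place of 3-methoxyphenyl on an aromatic carbon. Within the data shown here, none of the measured steps touches this aromatic carbon; all three concern a ring elsewhere in the shared core. They offer only an indirect hint: on that other ring, chloro left the number of compound 1 essentially unchanged, methoxy lowered it, and the exchange of chloro for methoxy lowered it as well. Going the opposite way, from methoxy to chloro, would on that analogy not lower the number, and compound 1 already stands near the top of the scale. Compound 4 is therefore expected to sit close to compound 1, with a number 4 percentage points lower from compound 1 to compound 4 (within the scatter) expected to remain within the scatter, and its value is estimated at 95%, in a range from 78% to 105%.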

Compound 4, a percentage reported as activity, at one concentration (the size of the read-out at that concentration, not a potency): 90.9%
Estimate against measurement, compound 4: 4.1 percentage points above; the range from low to high includes it.
By their numbers in this assay, from the lowest: compound 3; then compounds 4, 2 and 1 (each within the scatter of the next).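

In this assay, the exchange of 3-methoxyphenyl for 4-chlorophenyl, on the aromatic carbon next to the ring nitrogen and ortho to a cyano group, gives a number 8.1 percentage points lower from compound 1 to compound 4 (within the scatter). Within the data shown here, this is the first reading at this position, and it shows that the group there can change in both its substituent and that substituent's place on the phenyl ring without the number moving beyond the scatter, though this single step cannot separate those two changes. Nothing measured for these compounds offers an explanation for this outcome.

Still open, on these data alone, is whether a carboxylic acid or an amine on this phenyl ring, or a longer chain in its place, would also leave the number within the scatter of compound 1. The compounds shown also leave open whether the methoxy group on the other phenyl ring, which set compound 3 apart at 71.3%, would have a similar effect in a compound carrying the 4-chlorophenyl group at this position.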